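Phenyl in Place of Methyl on the Sulfonamide

The source may report more compounds than this note shows. Statements on the series, on what has been measured and on what is new or still open speak of the compounds shown alone.

Of the compounds shown here, three share a core and have been tested in a functional assay on HeLa cells (Homo sapiens) for antiproliferative activity, read by CCK-8 assay, with a stated time of 72 h; on this read-out higher numbers stand for weaker inhibition of growth and lower numbers for stronger inhibition of growth. Compound 1, `CCC1C(=O)N(C)c2cnc(Nc3ccc(S(=O)(=O)NCC(C)C)cc3)nc2N1c1ccn(C)n1`, gives 5310 nM in this assay. Compound 2, `CC[C@@H]1C(=O)N(C)c2cnc(-n3ccc4cc(C(N)=O)ccc43)nc2N1C1CCCC1`, gives 674 nM. Compound 3, `CC[C@@H]1C(=O)N(C)c2cnc(Nc3ccc(S(=O)(=O)NC)cc3)nc2N1C1CCCC1`, gives 148 nM, the lowest of the three numbers and therefore the strongest inhibitor of growth among them; its gap to compound 2 and its wider gap to compound 1 both lie beyond the usual scatter of this assay.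

Compound 4, `CC[C@@H]1C(=O)N(C)c2cnc(Nc3ccc(S(=O)(=O)Nc4ccccc4)cc3)nc2N1C1CCCC1`, has not yet been measured. It differs from compound 3 in one place: phenyl in place of methyl on a sulfonamide nitrogen. Compound 1 also carries a larger group on its sulfonamide nitrogen, but it differs from compound 3 in other places as well, so its weaker number cannot be traced to that group alone. Within the data shown here, no measured pair shows this exact change, so there is no step to lean on.

The expectation is a modest step towards a higher number, a 2.2-fold higher number from compound 3 to compound 4 (0.33 log units; beyond the scatter), with the possibility that it stays within the scatter. Compound 4 is estimated at 320 nM, within a range from 80 nM to 1300 nM.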

Compound 4, concentration for 50% growth inhibition: 5140 nM
Compound 4: middle estimate off by 16-fold (1.21 log units), on the low side, and the stated range ends below it.
By their numbers in this assay, from the lowest: compound 3; then compound 2; then compounds 4 and 1 (each within the scatter of the next).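

Among these compounds, this step is the first direct reading of what the sulfonamide nitrogen tolerates, since no earlier pair isolated that position. In this assay, phenyl in place of methyl produces a 35-fold higher number from compound 3 to compound 4 (1.54 log units; beyond the scatter) and so marks a large loss of growth inhibition from a single change, which shows that the group on this nitrogen matters greatly on the shared core. Neither group carries a hydrogen-bond donor, a hydrogen-bond acceptor or a net charge, so the counted difference lies in the added carbon atoms and the aromatic ring, although no measurement here gives a reason for the size of the step.

The two compounds alone cannot separate the effect of the added carbon atoms from that of the aromatic ring, and an ethyl group, a longer chain or a saturated cyclohexyl ring on the same nitrogen would help to tell these apart. A sulfonamide with only hydrogen on that nitrogen would show whether methyl itself helps or whether any group there, even one as small as methyl, already costs some activity.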